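Open hexyl chain in place of the cyclohexyl ring

This account rests on a few compounds, and the source may have more. Where it says the series, first, only, none or still open, it means among the compounds named here.

For the measured compounds named here, compound 2 `CCC(NC(=O)C(CC(C)C)NC(=O)OCc1ccccc1)C(=O)C(=O)NCC1CCCCC1` gives 44 nM in an assay on isolated protein (Oryctolagus cuniculus) for inhibition of Calpain-2 catalytic subunit (Homo sapiens), at pH 8.0; on this read-out higher numbers stand for weaker inhibition and lower numbers for stronger inhibition; compound 1 `CCCCNC(=O)C(=O)C(CC)NC(=O)C(CC(C)C)NC(=O)OCc1ccccc1` gives 50 nM in this assay, and the gap between the two lies within the scatter, so compound 2 stands level with its only neighbour. Compound 3 `CCCCCCCNC(=O)C(=O)C(CC)NC(=O)C(CC(C)C)NC(=O)OCc1ccccc1` carries hexyl in place of cyclohexyl on a saturated chain carbon bound to an amide-type nitrogen. Going by the values given here, the one measured step at this position, a 1.1-fold lower number from compound 1 to compound 2 (0.06 log units; within the scatter), did not move the number beyond the scatter. An open chain in place of the ring is therefore expected to give a 1.1-fold higher number from compound 2 to compound 3 (0.06 log units; within the scatter), no shift beyond the scatter. Compound 3 is estimated at 50 nM, in a range from 20 nM to 125 nM.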

Compound 3, inhibition constant: 67 nM
Beside the measured number, compound 3's estimate is 1.3-fold (0.13 log units) below it, within the range that was stated.
By their numbers in this assay, from the lowest: compounds 2, 1 and 3 (each within the scatter of the next).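

Ring and open chain are not told apart at this position in this assay: hexyl in place of cyclohexyl gives a 1.5-fold higher number from compound 2 to compound 3 (0.18 log units; within the scatter) and so leaves the number level. Propyl in place of hydrogen on a saturated chain carbon, four bonds along the chain from an amide-type nitrogen, gives a 1.3-fold higher number from compound 1 to compound 3 (0.13 log units; within the scatter) and also stays level, so neither the ring nor this added chain length separates the three compounds. Nothing available bears on why these compounds stand level.

Still open, from the compounds shown here alone, is whether a phenyl ring, a carboxylic acid or an amine in place of cyclohexyl would move the number beyond the scatter. Going by these compounds, a much longer chain, such as dodecyl, is equally open.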